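The source may report more compounds than this note shows. Statements on the series, on what has been measured and on what is new or still open speak of the compounds shown alone.

Three compounds of a shared core were measured in a functional assay on HT-29 cells (Homo sapiens) for inhibition, read by MTT assay, with a stated time of 72 h; on this read-out higher numbers stand for weaker inhibition and lower numbers for stronger inhibition. Compound 1 `COc1ccc(CCCNCc2c(OC)cc(Oc3ccc(Nc4ccccc4)cc3)cc2OC)cc1` gives 6890 nM in this assay. Compound 2 `COc1cc(Oc2cccc(Nc3ccccc3)c2)cc(OC)c1CN[C@H](C)c1ccccc1` gives 5120 nM in this assay, the second highest of the three numbers; compound 1 lies within the scatter of it, while compound 3 `COc1ccc([C@@H](C)NCc2c(OC)cc(Oc3cccc(Nc4ccccc4)c3)c(OC)c2OC)cc1`, which gives 1630 nM in this assay, lies beyond the scatter at a lower number. No pair of these compounds differs in a single place, so no measured step can be read directly.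

Compound 4 `COc1cc(Oc2cccc(Nc3ccccc3)c2)cc(OC)c1CNCc1ccc(O)cc1` is not yet measured in this assay. It differs from compound 2 by 4-hydroxybenzyl in place of 1-phenylethyl on an amine nitrogen. Among the measured compounds shown here, nothing among the measured compounds shows how such a change on the amine nitrogen is read in this assay; the one lower number belongs to compound 3, whose core differs from that of compound 2 in more than one place. Compound 4 is therefore expected to stay close to compound 2, with a step from compound 2 to compound 4 of a 1.0-fold lower number from compound 2 to compound 4 (0.01 log units; within the scatter), not beyond the scatter in either direction. The estimate for compound 4 in this assay is 5000 nM, with a range from 1800 nM to 14000 nM.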

Compound 4, half-maximal inhibitory concentration: 2180 nM
Estimate against measurement, compound 4: 2.3-fold (0.36 log units) above, within the range that was stated.
By their numbers in this assay, from the lowest: compounds 3 and 4 (each within the scatter of the next); then compounds 2 and 1 (each within the scatter of the next).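

In this assay, among the compounds shown here, the amine nitrogen proves to be a place where the substituent matters, with a 2.3-fold lower number from compound 2 to compound 4 (0.37 log units; beyond the scatter) giving a modest step beyond the scatter and the first change in a single place that can be read directly. That change removes 1-phenylethyl, with its defined stereocentre, and brings in 4-hydroxybenzyl, with its hydrogen-bond donor and acceptor. Nothing measured here connects the step to a particular property of either group.

The compounds shown leave open whether the step follows from the loss of the stereocentre or from the arrival of the hydroxyl group, a question that a plain benzyl group on the same nitrogen could help to separate. They also leave open whether 4-methoxybenzyl would keep the step and whether the same change would read alike on the cores of compound 1 and compound 3.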